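Chloro to Methyl on the Outer Aryl Ring

A few compounds are considered here, and "the series" means these few. Any claim that something is new, unique, unknown or untested is made for them only; others in the source may bear on it.

Compound 1 `CN(C)CCCNc1nc(-c2ccc(NC(=O)Nc3ccc(Cl)cc3)cc2)nc2c(Cl)c(Cl)sc12`: 1530 nM
Compound 2 `CN(C)CCNc1nc(-c2ccc(NC(=O)Nc3ccc(F)cc3)cc2)nc2ccsc12`: 330 nM

Of the compounds shown here, two have been tested in a functional assay on MKN-45 cells (Homo sapiens) for cytotoxicity, read by MTT assay, with a stated time of 72 h; on this read-out lower numbers stand for stronger inhibition and higher numbers for weaker inhibition. Compound 1 gives the higher of the two numbers, 1530 nM, meaning the weaker inhibition; compound 2 sits well lower, at 330 nM, a gap beyond the usual scatter. The two differ in several places at once, so no single change can be credited with that gap.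

Compound 3 `Cc1ccc(NC(=O)Nc2ccc(-c3nc(NCCCN(C)C)c4sc(Cl)c(Cl)c4n3)cc2)cc1` is the next compound to be measured in this assay. It is built from compound 1 by one swap: methyl in place of chloro on an aromatic carbon, para to a large group. Neither group carries a net charge. Among the measured compounds shown here, no measured pair shows this exact change, so there is nothing to scale an expectation from. The expected step is small, likely within the scatter: a 1.2-fold lower number from compound 1 to compound 3 (0.07 log units; within the scatter). On that basis compound 3 is estimated at 1300 nM, within a range from 500 nM to 3500 nM.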

Compound 3, half-maximal inhibitory concentration: 3700 nM
Estimate against measurement, compound 3: 2.8-fold (0.45 log units) below; measured number above the stated range.
By their numbers in this assay, from the lowest: compound 2; then compound 1; then compound 3.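

In this assay, the swap of chloro for methyl exchanges one heavy atom for one heavy atom, with no net charge on either side, yet it gives a 2.4-fold higher number from compound 1 to compound 3 (0.38 log units; beyond the scatter). Among the compounds shown here, this is the first comparison that differs in one place only, so it is the first sign that the group on this outer ring affects the read-out, with chloro giving the stronger inhibition of the two. Nothing measured here explains why the step runs in this direction.

Compound 2 carries fluoro on this ring but also differs from compound 1 elsewhere, so it cannot show how fluoro compares with chloro. Going by these compounds, whether a methoxy group, an amine or a carboxylic acid in the same place would lower or raise the number remains open.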